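Swapping nitro for amino on a measured amide

This account rests on a few compounds, and the source may have more. Where it says the series, first, only, none or still open, it means among the compounds named here.

Of the compounds shown here, three have been tested so far in a functional assay on T47D cells (Homo sapiens) for antiproliferative activity, read by MTT assay, with a stated time of 72 h (a lower number here means a stronger inhibitor, a higher number a weaker inhibitor), and only one gives a true number. Compound 1 `COc1cc(-c2nccn2C)cc(OC)c1OC` gives > 100000 nM in this test, which is a limit of the assay and not a number. Compound 2 `COc1ccc(OC(=O)c2cc(OC)c(OC)c(OC)c2)cc1N` gives > 100000 nM as well, again only a limit. Among the compounds with values here, compound 3 `COc1ccc(C(=O)Nc2cc(OC)c(OC)c(OC)c2)cc1[N+](=O)[O-]` gives 6000 nM as the only measured number, so it is the natural starting point for the next comparison.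

Compound 4 `COc1ccc(C(=O)Nc2cc(OC)c(OC)c(OC)c2)cc1N` differs from compound 3 in one place, counted in amino in place of nitro on an aromatic carbon and amounting to amino in place of nitro on an aromatic carbon, ortho to a methoxy group and meta to a large group. Within the data shown here, no measured pair shows this exchange directly, so any forecast rests on thin ground. Compound 2 also carries an amino group and sits at the limit > 100000 nM in this assay, so a loss of activity cannot be ruled out. A modest gain in strength is still what is expected, with the estimated change being a 3.0-fold lower number from compound 3 to compound 4 (0.48 log units; beyond the scatter) in this test. For compound 4 the expected value is 2000 nM with an estimated range from 200 nM to 30000 nM as the likely span.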

Compound 4, half-maximal inhibitory concentration: > 100000 nM
Compound 4 ended at the assay's limit; the forecaster's own chance of this, stated with the estimate: 15%; middle value at least 50-fold (1.69 log units) away from the limit.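

In this assay compound 4 gives > 100000 nM, which is a limit of the assay and not a number. The earlier compounds shown here offered no single exchange to read, but here amino in place of nitro, on an aromatic carbon ortho to a methoxy group and meta to a large group, gives an at least 16-fold higher number from compound 3 to compound 4 (1.22 log units; beyond the scatter), so the one measured activity in this set does not survive this change at this carbon. The size of the step is only a minimum, as the true value of compound 4 lies somewhere past the end of the test range, and that ceiling is a common result in this small set: the limit of > 100000 nM in this assay, at which 3 of the 4 values shown sit.

The compounds shown leave open whether activity requires the nitro group itself or simply the absence of the amino group, a question that a nitrile, a chlorine atom or an acetamide on the same carbon could help to settle. A methylamino group there could also show whether a small change to the amino group brings back a measurable value in this assay.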